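This account rests on a few compounds, and the source may have more. Where it says the series, first, only, none or still open, it means among the compounds named here.

Going by the values given here, compound 3 `CC[C@@H](Nc1c(C#N)c(-c2ccc(Br)cc2)nc2cnccc12)C(N)=O` is one of three compounds measured in a physicochemical assay for lipophilicity, read by HPLC, at pH 7.5; a lower number here means a more polar compound, a higher number a more lipophilic compound. Compound 3 gives 2.2, the highest of the three numbers. Compound 1 `CC(C)(CC(N)=O)c1c(C#N)c(-c2ccc(Br)cc2)nc2cnccc12` gives 2.1, which lies within the scatter of compound 3, and compound 2 `CC[C@@H](Nc1c(C#N)c(-c2ccc(Br)cc2)nc2cnccc12)C(=O)O` gives 1.6, so that a number 0.60 log units higher from compound 2 to compound 3 (beyond the scatter). Compound 4 `CC[C@@H](Nc1c(C#N)c(-c2ccc(-c3ccc(Cl)cc3)cc2)nc2cnccc12)C(N)=O` differs from compound 3 in one place: 4-chlorophenyl in place of bromo on an aromatic carbon. Among the compounds with values here, neither measured step, a number 0.50 log units lower from compound 1 to compound 2 (beyond the scatter) nor a number 0.10 log units higher from compound 1 to compound 3 (within the scatter), touches the bromo group; both concern a different part of the molecule, so no measured step covers this change. What enters is a 4-chlorophenyl group with its aromatic ring, what leaves is a single bromo, and on that basis a rise is expected. For compound 4 the expected step is a number 1.10 log units higher from compound 3 to compound 4 (beyond the scatter). Compound 4 is estimated at 3.3, with a range from 2.7 to 3.9.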

Compound 4, distribution coefficient: 3.1
The estimate for compound 4 lay 0.20 log units above the measured number; the range from low to high includes it.
By their numbers in this assay, from the lowest: compound 2; then compounds 1 and 3 (each within the scatter of the next); then compound 4.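

In this assay, 4-chlorophenyl in place of bromo gives a number 0.90 log units higher from compound 3 to compound 4 (beyond the scatter). This is the first change shown on this aromatic carbon, para to a large group, and it moves the number further than either step among the earlier compounds, which all concern a different part of the molecule. Nothing measured here explains the size of this step. The compounds shown leave open how an amine or a morpholine ring at this position would read in this assay, and whether the same change would give a similar step with the carboxylic acid of compound 2.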